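Methoxy for hydroxy on the benzylic carbon of compound 2

This account rests on a few compounds, and the source may have more. Where it says the series, first, only, none or still open, it means among the compounds named here.

Of the compounds shown here, two have been measured in a functional assay on M21 cells (Homo sapiens) for antiproliferative activity, with a stated time of 48 h; a lower number here means a stronger inhibitor, a higher number a weaker inhibitor. Compound 1 `CCCCC(OC)c1cccc(NC(=O)NC(=O)CC)c1` carries a methoxy group on the benzylic carbon and an acylurea on the ring. Compound 2 `CCCCC(O)c1cccc(NC(=O)CCCl)c1` carries a free hydroxy group at the same carbon and a chloropropanamide on the ring. In this assay compound 1 reaches only the limit of the assay, > 100000 nM. In this assay compound 2 likewise gives only a limit, > 100000 nM. Compound 2 therefore stands at the limit of > 100000 nM in this assay, at which 2 of the 2 values shown sit, rather than at a number, and nothing further can be said about its rank.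

Compound 3 `CCCCC(OC)c1cccc(NC(=O)CCCl)c1` is not yet measured. It differs from compound 2 by methyl in place of hydrogen on an oxygen on a saturated carbon; cut one bond further out the change reads hydroxy to methoxy. Within the data shown here, no measured step of this kind exists. Compound 1, which already carries the methoxy group, sits at the same limit, so no step beyond the scatter is expected in either direction. Compound 3 is expected to give 100000 nM, with a range of 30000 nM to 300000 nM, most likely reported again as a limit. The expected step is a number no higher from compound 2 to compound 3 (the limit leaves the size open), none beyond the scatter.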

Compound 3, half-maximal inhibitory concentration: > 100000 nM
Compound 3 was reported as a limit; the forecaster's own chance of this, stated with the estimate: 85%; the middle value lies on the limit itself.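

Among these compounds, compound 1, compound 2 and compound 3 all give only limits in this assay, so no step among them can be read: the limit of > 100000 nM in this assay, at which 3 of the 3 values shown sit. The compounds shown leave open whether hydroxy to methoxy, or 2-chloroethyl in place of propanoylamino, changes the read-out at all, and which features of this series would give a measurable value.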